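This account rests on a few compounds, and the source may have more. Where it says the series, first, only, none or still open, it means among the compounds named here.

Three compounds have been measured in a functional assay on HaCaT cells (Homo sapiens) for antiproliferative activity, read by sulforhodamine B assay, with a stated time of 3 days; a higher number here means a weaker inhibitor, a lower number a stronger inhibitor:
compound 1 `COC(=O)c1cc(CCc2cc(OC)ccc2N(C)C)ccc1O` gives 650 nM;
compound 2 `COC(=O)c1cc(CCc2cc(N(C)C)ccc2OC)ccc1O` gives 920 nM;
compound 3 `COC(=O)c1cc(CCc2cc(C(C)=O)ccc2OC)ccc1O` gives 660 nM.

Compound 1 and compound 2 are built from the same atoms joined differently; the difference between their cores is not broken down here. Compound 2 and compound 3 differ in one place, (acetyl in place of dimethylamino on an aromatic carbon), and this change gave a 1.4-fold lower number from compound 2 to compound 3 (0.14 log units; within the scatter). Compound 4 `COC(=O)c1cc(CCc2cc(OC)ccc2C(C)=O)ccc1O` has not yet been measured. It differs from compound 1 by acetyl in place of dimethylamino on an aromatic carbon, the same kind of change, though here the entering group sits ortho to a large group, whereas in compound 3 it sits meta to a large group. The earlier change gave a 1.4-fold lower number from compound 2 to compound 3 (0.14 log units; within the scatter), and on that the expectation for compound 4 rests. For compound 4 the expected step is a 1.2-fold lower number from compound 1 to compound 4 (0.07 log units; within the scatter). Compound 4 is therefore estimated at 550 nM, with a likely range from 250 nM to 1200 nM.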

Compound 4, half-maximal inhibitory concentration: 41 nM
Estimate against measurement, compound 4: 13-fold (1.13 log units) above; measured number outside the range, below it.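

In this assay, acetyl in place of dimethylamino gave a 16-fold lower number from compound 1 to compound 4 (1.20 log units; beyond the scatter), so this change did not carry over at the same size from one core to the other: the same change on two cores in this assay, a 1.4-fold lower number (0.14 log units; within the scatter) from compound 2 to compound 3 and a 16-fold lower number (1.20 log units; beyond the scatter) from compound 1 to compound 4, 11-fold (1.06 log units) apart, beyond the scatter of two such steps

On these two pairs, then, the step seen on one core was a poor guide to the step on the other. Two pairs do not show why the steps differ, nor whether it matters that the acetyl in compound 4 sits ortho to a large group and para to a methoxy group.

Still open, going by these compounds, is whether a group other than acetyl in that place on the core of compound 1, such as an amide or a carboxylic acid, would give a similarly low number.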